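Crotonamide in Place of Acrylamide on a Shared Core

The source may hold more compounds than are shown below. What is called first, only, known or untested is meant among the compounds shown, and "the series" means these compounds.

Compound 1 `C/C=C/C(=O)Nc1ccc(Cn2nc(-c3ccc(Oc4ccccc4)cc3)cc2C(=O)O)cc1`: > 60000 nM in a functional assay on JeKo-1 cells (Homo sapiens) for inhibition, read by luminescence and CellTiter-Glo, with a stated time of 72 h; a higher number here means a weaker inhibitor, a lower number a stronger inhibitor
Compound 2 `CCOC(=O)c1cc(-c2ccc(Oc3ccccc3)cc2)nn1Cc1cccc(NC(=O)CCl)c1`: 400 nM
Compound 3 `C=CC(=O)Nc1ccc(Cn2nc(-c3ccc(Oc4ccccc4)cc3)cc2C(=O)OCC)cc1`: 10900 nM

The value of compound 1 is a limit of this assay, not a number. Among the measured numbers compound 3 stands highest, and the only step shown, a 27-fold higher number from compound 2 to compound 3 (1.44 log units; beyond the scatter), leads to it. Compound 4 `C/C=C/C(=O)Nc1ccc(Cn2nc(-c3ccc(Oc4ccccc4)cc3)cc2C(=O)OCC)cc1` differs from compound 3 by prop-1-en-1-yl in place of vinyl on a carbonyl carbon. No measured step touches the same change: the one step shown alters both the group on the amide and its place on the ring. Compound 1, which carries the same prop-1-en-1-yl group on an acid, reached only a limit (the limit of > 60000 nM in this assay, at which 1 of the 3 values shown sits). The step from compound 3 to compound 4 is therefore expected to weaken, a 2.3-fold higher number from compound 3 to compound 4 (0.36 log units; beyond the scatter), and compound 4 is estimated at 25000 nM (range 8000 nM to 60000 nM).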

Compound 4, half-maximal inhibitory concentration: 52500 nM
Compound 4: middle estimate off by 2.1-fold (0.32 log units), on the low side; low and high end bracket the measured number.
By their numbers in this assay, from the lowest: compound 2; then compound 3; then compound 4. At a limit, above all of these: compound 1.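

In this assay, within the data shown here, prop-1-en-1-yl in place of vinyl on a carbonyl carbon gives a 4.8-fold higher number from compound 3 to compound 4 (0.68 log units; beyond the scatter), the first reading of this change alone. The gap to the chloromethyl compound grows to a large one, a 130-fold higher number from compound 2 to compound 4 (2.12 log units; beyond the scatter), though there the group and its place on the ring change together. Compound 1 stands at > 60000 nM, which is a limit and not a number. As far as these compounds go, the step that puts ethyl in place of hydrogen on the oxygen of the acid can be given only as an at least 1.1-fold lower number from compound 1 to compound 4 (0.05 log units; that floor lies within the scatter), so its true size stays unknown.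

From the compounds shown here alone, what an amine or a longer chain on that carbonyl carbon would give stays open, as does how much of the gap to compound 2 belongs to the group and how much to its place on the ring.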